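Biaryl carbinol series: cytotoxicity working notes

The source may hold more compounds than are shown below. What is called first, only, known or untested is meant among the compounds shown, and "the series" means these compounds.

Measured so far in an ADME assay on HeLa Rh cells (Homo sapiens) for cytotoxicity, read by microscopy; on this read-out lower numbers stand for higher toxicity in this test and higher numbers for lower toxicity in this test:
compound 1 `COc1cc(CC(O)c2ccc(-c3ccc([N+](=O)[O-])cc3)cc2)c([N+](=O)[O-])cc1OC`, 21000 nM
compound 2 `COc1ccc(-c2ccc(C(O)Cc3cc(OC)c(OC)cc3[N+](=O)[O-])cc2)cc1`

Compound 2 gives only a limit in this assay, namely > 244000 nM; see (the limit of > 244000 nM in this assay, at which 1 of the 2 values shown sits). Among the measured compounds shown here, the single measured step is an at least 11-fold higher number from compound 1 to compound 2 (1.06 log units; beyond the scatter), a change on the distal ring. Compound 3 `COc1cc(CC(O)c2ccc(-c3cccc(F)c3)cc2)c([N+](=O)[O-])cc1OC` is the next to be measured; it differs from compound 2 in that (3-fluorophenyl in place of 4-methoxyphenyl on an aromatic carbon). For the measured compounds named here, no measured step covers this exchange, so the expectation rests only on the range between compound 1 and compound 2. Compound 3 is expected to move back toward a number, with an estimated at least 2.4-fold lower number from compound 2 to compound 3 (0.38 log units; beyond the scatter). Compound 3 is estimated at 100000 nM, range 25000 nM to 300000 nM.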

Compound 3, half-maximal cytotoxic concentration: 7400 nM
The estimate for compound 3 lay 14-fold (1.13 log units) above the measured number, and the stated range ends above it.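

In this assay the aryl group at this position again sets the read-out: 3-fluorophenyl in place of 4-methoxyphenyl gives an at least 32-fold lower number from compound 2 to compound 3 (1.51 log units; beyond the scatter). 3-Fluorophenyl in place of 4-nitrophenyl gives a 2.8-fold lower number from compound 1 to compound 3 (0.45 log units; beyond the scatter), so 4-nitrophenyl is not required for a measured number at this position. The first step is read against a limit for compound 2, not a number: the limit of > 244000 nM in this assay, at which 1 of the 3 values shown sits.

Compound 3 changes both the substituent and its place on the ring, and these two changes cannot be separated here. On these data alone, how an unsubstituted phenyl, or an amine or a carboxylic acid on this ring, would read remains open.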